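Trimming a Dimethylamino Tail from Compound 2

A few compounds are considered here, and "the series" means these few. Any claim that something is new, unique, unknown or untested is made for them only; others in the source may bear on it.

Among the measured compounds shown here, compound 2, `CN(C)CCCN(Cc1ccccc1)c1cccc(C(=O)N2CCc3ccc(OS(N)(=O)=O)cc3C2)c1`, is the middle of the three compounds measured so far. In an assay on HEK293 cells for inhibition of Steryl-sulfatase (Homo sapiens), tested at 1 uM (a lower number here means a weaker effect, a higher number a stronger effect of the compound at the concentration tested), compound 2 gives 26%. Compound 1, `CN(C)CCN(CCN(C)C)c1ccc(C(=O)N2CCc3ccc(OS(N)(=O)=O)cc3C2)cc1`, gives 15.9%, and compound 3, `CCN(Cc1ccccn1)c1ccc(C(=O)N2CCc3ccc(OS(N)(=O)=O)cc3C2)cc1`, gives 87.7%, so compound 2 stands second highest, much closer to compound 1 than to compound 3.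

The new compound 4, `CCCN(Cc1ccccc1)c1cccc(C(=O)N2CCc3ccc(OS(N)(=O)=O)cc3C2)c1`, differs from compound 2 in a single place: hydrogen in place of dimethylamino on a saturated chain carbon, three bonds along the chain from a nitrogen on an aromatic ring. The propyl chain itself stays; only its dimethylamino end is taken away.

For the measured compounds named here, one measured step bears on this. Going from compound 1 to compound 3 also strips dimethylamino-bearing chains off the nitrogen attached to the aromatic ring, although other parts of that group change at the same time, and the result was a number 71.8 percentage points higher from compound 1 to compound 3 (beyond the scatter). That step points upward for compound 4, but it bundles several changes, and no measurement shows the removal of one dimethylamino group on its own, so the size is uncertain.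

Compound 4 is therefore expected to inhibit more strongly than compound 2, by a step of about a number 34 percentage points higher from compound 2 to compound 4 (beyond the scatter). The estimate for compound 4 is 60%, with a range from 30% to 90%.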

Compound 4, a percentage reported as inhibition, at one concentration (the size of the read-out at that concentration, not a potency): 67.4%
For compound 4 the middle estimate is 7.4 percentage points below the measured one; the range from low to high includes it.
By their numbers in this assay, from the lowest: compound 1; then compound 2; then compound 4; then compound 3.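

In this assay, taking off only the dimethylamino end of the chain, with the propyl chain and the rest of the molecule unchanged, gives a number 41.4 percentage points higher from compound 2 to compound 4 (beyond the scatter) and so has a large effect on its own. The earlier step from compound 1 to compound 3 changed several parts of the group at once, so this is the only pair shown that isolates the loss of dimethylamino on a saturated chain carbon, three bonds along the chain from a nitrogen on an aromatic ring. No measurement at hand explains why the number rises at this position.

The compounds shown leave open whether this rise is specific to the dimethylamino group or would also follow from removing another group at the chain end, which a propyl chain ending in a hydroxyl group, a primary amine or a carboxylic acid could test, as a shorter ethyl or a longer butyl chain could test the role of chain length. They also leave open whether the same removal would have a similar effect with a group other than benzyl on that nitrogen.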